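The compounds below may be only part of what the source reports. "The series", "measured", "known", "first", "only" and "open" are said of these compounds alone.

Compounds measured so far:
compound 1, `Nc1ccccc1NC(=O)c1ccc(CSC(=S)N2CCN(Cc3ccccn3)CC2)cc1`: 20.7% in a functional assay on A-375 cells (Homo sapiens) for antiproliferative activity, read by CCK-8 assay, with a stated time of 72 h, tested at 2 uM; on this read-out lower numbers stand for a weaker effect and higher numbers for a stronger effect at the one concentration tested
compound 2, `Nc1ccccc1NC(=O)c1ccc(CSC(=S)N2CCN(Cc3ccccc3)CC2)cc1`: 10.6% in this assay

Compound 2 stands lowest of the two numbers shown; its only neighbour, compound 1, lies higher by a step beyond the scatter. Among the measured compounds shown here, the single measured step, a number 10.1 percentage points lower from compound 1 to compound 2 (beyond the scatter), concerns the group on the saturated chain carbon bound to the ring amine nitrogen. Compound 3, `Nc1ccccc1NC(=O)c1ccc(CSC(=S)N2CCN(c3cccnc3)CC2)cc1`, differs from compound 2 in another way: pyridin-3-yl in place of benzyl on an amine nitrogen in a ring. Here the benzyl group leaves altogether and a pyridin-3-yl ring sits directly on the ring nitrogen, so the measured step bears on it only loosely: it shows that in this region a pyridine ring went with a higher number than a phenyl ring. On that basis a modest rise is expected, a number 7.4 percentage points higher from compound 2 to compound 3 (within the scatter), though a step within the scatter cannot be excluded. Compound 3 is therefore expected to give 18%, within 5% to 32%.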

Compound 3, a percentage reported as inhibition, at one concentration (the size of the read-out at that concentration, not a potency): 40.5%
For compound 3 the middle estimate is 22.5 percentage points below the measured one; measured number outside the range, above it.
By their numbers in this assay, from the lowest: compound 2; then compound 1; then compound 3.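

In this assay, pyridin-3-yl in place of benzyl on the amine nitrogen in the ring gave a number 29.9 percentage points higher from compound 2 to compound 3 (beyond the scatter), and pyridin-3-yl in place of (pyridin-2-yl)methyl gave a number 19.8 percentage points higher from compound 1 to compound 3 (beyond the scatter). This position therefore accepts a ring set directly on the nitrogen, with no saturated chain carbon, and compound 3 stands highest of the three, beyond the scatter from both others. No measurement shown here explains this rise.

Going by these compounds, both steps change the link and the ring at once, and compound 1 and compound 3 also differ in where the ring nitrogen sits, so the share of each change stays open. On these data alone, whether phenyl or pyridin-4-yl set directly on the amine nitrogen would go with a similar number also remains open.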